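The source may hold more compounds than are shown below. What is called first, only, known or untested is meant among the compounds shown, and "the series" means these compounds.

Measured so far:
- compound 1 `C[C@@H]1CCCN1c1c(C#N)c2c(N)nc(Nc3cn[nH]c3)nc2n1C`: 0.2 nM
- compound 2 `C[C@@H]1CCCN1c1c(C#N)c2c(N)ncnc2n1C`: 0.4 nM

In an assay on isolated protein for binding affinity to Leucine-rich repeat serine/threonine-protein kinase 2 (Homo sapiens), read by TR-FRET and LanthaScreen, with a stated time of 2 h (a lower number here means a stronger inhibitor, a higher number a weaker inhibitor), compound 1 gives 0.2 nM and compound 2 gives 0.4 nM. Compound 2 stands at the higher of the two numbers, but a 2.0-fold higher number from compound 1 to compound 2 (0.30 log units; within the scatter) is within the scatter, so the two cannot be ordered. The change from compound 2 to compound 3 `C[C@H]1CCCN1c1c(C#N)c2c(N)ncnc2n1C` is the two compounds have the same atoms and bonds and differ only in configuration as drawn: 1 of 1 stereo elements differ; a stereocentre at a saturated ring carbon is drawn R in compound 2 and S in compound 3. Going by the values given here, no measured step bears on this change: the only step recorded, a 2.0-fold higher number from compound 1 to compound 2 (0.30 log units; within the scatter), concerns a substituent and not a configuration. The expectation therefore rests on the observation that inversion of a single stereocentre often shifts affinity, with no guide to its size. A weaker number is expected for compound 3, by a 10-fold higher number from compound 2 to compound 3 (1.00 log units; beyond the scatter), with a broad range. Compound 3 is estimated at 4 nM, between 0.4 nM and 40 nM.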

Compound 3, inhibition constant: 136 nM
For compound 3 the middle estimate is 34-fold (1.53 log units) below the measured one; measured number above the stated range.
By their numbers in this assay, from the lowest: compounds 1 and 2 (each within the scatter of the next); then compound 3.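

In this assay, inverting the stereocentre at the saturated ring carbon gives a 340-fold higher number from compound 2 to compound 3 (2.53 log units; beyond the scatter). Going by these compounds alone, the only earlier step, a 2.0-fold higher number from compound 1 to compound 2 (0.30 log units; within the scatter), gave no readable difference, so this is the first change with a readable effect, and it shows that the R configuration as drawn is strongly preferred over the S configuration in this pair. The gap can be assigned to configuration alone, because nothing else separates the pair: the fact that compounds 2 and 3 differ only in the configuration as drawn.

Whether the same preference holds with (1H-pyrazol-4-yl)amino present remains open, since the compounds shown include that group only with the R configuration. Also open, as far as these compounds go, is how the numbers would respond to an ethyl group or a hydroxymethyl group in place of the methyl on that saturated ring carbon.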